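A few compounds are considered here, and "the series" means these few. Any claim that something is new, unique, unknown or untested is made for them only; others in the source may bear on it.

Compound 2 `COc1cc(OC)c2c(=O)c(OCCCCOc3ccc(/C=C/C(=O)/C=C/c4scnc4C)cc3)c(-c3cc(OC)c(OC)c(OC)c3)oc2c1` stands at the weaker end of the two numbers available: in a functional assay on MGC-803 cells (Homo sapiens) for antiproliferative activity, read by MTT assay, with a stated time of 48 h (on this read-out higher numbers stand for weaker inhibition and lower numbers for stronger inhibition), compound 2 gives 54600 nM, while compound 1 `O=C(/C=C/c1ccc(Oc2cc(=O)oc3ccccc23)cc1)/C=C/c1ccccn1` gives 19400 nM in this assay, a gap that lies beyond the usual scatter. Among the compounds with values here, compound 1 and compound 2 differ in several places at once, so their two values show only that compound 1 inhibits more strongly. Compound 3 `COc1cc(OC)c2c(=O)c(OCCCCOc3ccc(/C=C/C(=O)/C=C/c4ccccn4)cc3)c(-c3cc(OC)c(OC)c(OC)c3)oc2c1` has not yet been measured. It differs from compound 2 in one place: pyridin-2-yl in place of 4-methyl-1,3-thiazol-5-yl on a double-bonded chain carbon bound to a double-bonded chain carbon. Within the data shown here, no measured pair isolates this exchange, so its effect cannot be read from a directly comparable step. Because compound 1, which carries the same pyridin-2-yl end, gives 19400 nM, a modest move toward stronger inhibition is expected, though a step that stays within the scatter is equally plausible. Compound 3 is therefore expected to give 35000 nM, within 12000 nM to 100000 nM, in this assay. The expected step is a 1.6-fold lower number from compound 2 to compound 3 (0.19 log units; within the scatter).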

Compound 3, half-maximal inhibitory concentration: 1960 nM
Beside the measured number, compound 3's estimate is 18-fold (1.25 log units) above it; the whole stated range lies above it.
By their numbers in this assay, from the lowest: compound 3; then compound 1; then compound 2.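

The exchange of 4-methyl-1,3-thiazol-5-yl for pyridin-2-yl on a double-bonded chain carbon bound to a double-bonded chain carbon gives a 28-fold lower number from compound 2 to compound 3 (1.44 log units; beyond the scatter) in this assay and is a large step. Within the data shown here, this pair is the first to isolate this position, and it shows that this one end group, with the rest of the molecule unchanged, can shift the read-out strongly toward stronger inhibition, which the earlier two compounds, differing in several places at once, could not show. No evidence at hand accounts for the size of this step.

From the compounds shown here alone, it remains open whether a phenyl, pyridin-3-yl or pyridin-4-yl group at this place would give a similar number. The compounds shown also leave open whether the same exchange would carry the same weight on the core of compound 1 or with a longer chain linking the shared core.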